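The source may hold more compounds than are shown below. What is called first, only, known or untested is meant among the compounds shown, and "the series" means these compounds.

Compound 1 `COc1ccc(-c2cnc(NC(=O)c3ccccc3F)n2C)cc1`: > 100000 nM
Compound 2 `COc1ccc(-c2cnc(NC(=O)c3ccc(C)cc3)n2C)cc1`: > 100000 nM
Compound 3 `COc1ccc(-c2cnc(NC(=O)c3ccc(F)cc3)n2C)cc1`: >= 50000 nM

In a toxicity assay on THP-1 cells (Homo sapiens) for inhibition (a higher number here means that more compound is tolerated, a lower number that less compound is tolerated), compound 1 gives > 100000 nM, a limit of the assay. Compound 2 gives > 100000 nM in this assay, likewise a limit. Compound 3 sits at >= 50000 nM in this assay, a limit as well; every value here is a limit, so compound 3 stands nowhere readable relative to the others. The steps a step that the two limits leave unreadable from compound 1 to compound 2, a step that the two limits leave unreadable from compound 1 to compound 3 and a step that the two limits leave unreadable from compound 2 to compound 3 are therefore all unreadable, as the limit of > 100000 nM in this assay, at which 2 of the 3 values shown sit, and the limit of >= 50000 nM in this assay, at which 1 of the 3 values shown sits, show.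

Compound 4 `COc1ccc(-c2cnc(NC(=O)c3ccc(C#N)cc3)n2C)cc1` differs from compound 3 by cyano in place of fluoro on an aromatic carbon. For the measured compounds named here, no measured step bears readably on this change. The step that the limit leaves unreadable from compound 3 to compound 4 is expected to show no readable size. Compound 4 is estimated at 100000 nM, between 40000 nM and 250000 nM, most likely again reported only as a limit.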

Compound 4, half-maximal cytotoxic concentration: > 100000 nM
Compound 4: a limit, no number (the forecaster's own chance of this, stated with the estimate: 85%); the middle value sits exactly at the limit.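

For the compounds shown here, compound 4 gives only a limit in this assay, as do compound 1, compound 2 and compound 3, so no step involving compound 4 can be read. Going by these compounds, the tolerated concentration of all four compounds remains open, as does whether cyano, fluoro or methyl changes it.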